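Methoxy to Hydroxy in a Cell-Growth Screen

This account rests on a few compounds, and the source may have more. Where it says the series, first, only, none or still open, it means among the compounds named here.

Three compounds sharing one core were tested in a functional assay on A498 cells (Homo sapiens) for cytotoxicity, read by sulforhodamine B assay, with a stated time of 48 h, tested at 0.001 uM; on this read-out higher numbers stand for a weaker effect at the one concentration tested and lower numbers for a stronger effect. Compound 1 `COc1cc(C)cc(-c2c(-c3ccnc(-c4ccc(N(C)C)cc4)c3)cnn2CC#N)c1` gives 94%. Compound 2 `COc1cc(C)cc(-c2nn(CC#N)cc2-c2ccnc(-c3ccc(N(C)C)cc3)c2)c1` gives 91%, and compound 3 `COc1cc(C)cc(-c2nn(CC#N)cc2-c2ccc(-c3cccc(C(C)=O)c3)nc2)c1` gives 76%.

On these numbers compound 2 stands second highest of the three. Its nearest neighbour is compound 1, whose number lies within the usual scatter of such measurements, and its furthest is compound 3, whose number is lower by more than the scatter. A new compound, compound 4 `Cc1cc(O)cc(-c2nn(CC#N)cc2-c2ccnc(-c3ccc(N(C)C)cc3)c2)c1`, has not yet been measured. It differs from compound 2 in a single place: hydrogen in place of methyl on an oxygen on an aromatic ring.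

Within the data shown here, no pair of measured compounds differs in this one way, so the size of the step cannot be read off from them. All three measured numbers sit high, which here means a weak effect at the one low concentration tested, and nothing among them points to a swap on an oxygen on an aromatic ring moving the read-out beyond the scatter. Compound 4 is expected to stay close to compound 2, with an estimated step of a number 1 percentage points lower from compound 2 to compound 4 (within the scatter). For compound 4 the estimate in this assay is 90%, ranging from 76% to 100%.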

Compound 4, a percentage reported as activity, at one concentration (the size of the read-out at that concentration, not a potency): 101%
For compound 4 the middle estimate is 11 percentage points below the measured one; measured number outside the range, above it.
By their numbers in this assay, from the lowest: compound 3; then compounds 2, 1 and 4 (each within the scatter of the next).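

In this assay, going from methoxy to hydroxy on the aromatic ring gives a number 10 percentage points higher from compound 2 to compound 4 (within the scatter). Among these compounds, this is the first direct look at this position, and it shows that removing the methyl from the oxygen, leaving 3-hydroxy-5-methylphenyl in place of 3-methoxy-5-methylphenyl, brings no stronger effect at the one low concentration tested. Nothing available here explains the size of this step.

Among the compounds shown here, this swap has been seen only with the groups of compound 2, so its size with the other groups of compound 3, which gives 76%, remains open. Also open, on these data alone, is whether a longer chain on that oxygen, such as ethoxy, or an amine in place of the hydroxy group would move the read-out beyond the usual scatter.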